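Sulfur-Linked Benzyl Replaces Cyclopentyloxy on the Shared Core

A few compounds are considered here, and "the series" means these few. Any claim that something is new, unique, unknown or untested is made for them only; others in the source may bear on it.

Compound 1 `CC(C(=O)NCc1ccc(C(C)(C)C)nc1N1CCCC1)c1ccc(NS(C)(=O)=O)c(F)c1`: 1.2 nM
Compound 2 `CC(C(=O)NCc1ccc(C(C)(C)C)nc1OC1CCCC1)c1ccc(NS(C)(=O)=O)c(F)c1`: 1.5 nM
Compound 3 `CC(C(=O)NCc1ccc(C(C)(C)C)nc1OCc1ccc(F)cc1)c1ccc(NS(C)(=O)=O)c(F)c1`: 0.8 nM

All three compounds were tested in an assay on cells for antagonist activity at transient receptor potential cation channel subfamily V member 1 (Homo sapiens), read by FLIPR and calcium flux, with a stated time of 6 min; a lower number here means a stronger inhibitor, a higher number a weaker inhibitor. Compound 2 gives the highest number of the three, but its neighbours sit close: a 1.3-fold higher number from compound 1 to compound 2 (0.10 log units; within the scatter) and a 1.9-fold lower number from compound 2 to compound 3 (0.27 log units; within the scatter), so none of the three can be called stronger or weaker than the others.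

Compound 4 `CC(C(=O)NCc1ccc(C(C)(C)C)nc1SCc1ccccc1)c1ccc(NS(C)(=O)=O)c(F)c1` has not yet been measured. Relative to compound 2 the change is benzylsulfanyl in place of cyclopentyloxy on an aromatic carbon.

Within the data shown here, the steps that bear on this change all concern the same position on the shared core. Exchanging pyrrolidin-1-yl for cyclopentyloxy (a 1.3-fold higher number from compound 1 to compound 2 (0.10 log units; within the scatter)), for (4-fluorobenzyl)oxy (a 1.5-fold lower number from compound 1 to compound 3 (0.18 log units; within the scatter)), or cyclopentyl for 4-fluorobenzyl on that oxygen (a 1.9-fold lower number from compound 2 to compound 3 (0.27 log units; within the scatter)) all stayed within the scatter. The position therefore seems tolerant of quite different groups, at least among these three compounds. Compound 3 carries a benzyl-type group at this position and gives 0.8 nM, which supports a similar outcome for the benzylsulfanyl group.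

The expected step is therefore a 1.5-fold lower number from compound 2 to compound 4 (0.18 log units; within the scatter), no larger than the scatter. Compound 4 is estimated at 1 nM in this assay, with a range from 0.4 nM to 2.5 nM.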

Compound 4, inhibition constant: 4 nM
Beside the measured number, compound 4's estimate is 4.0-fold (0.60 log units) below it; the whole stated range lies below it.
By their numbers in this assay, from the lowest: compounds 3, 1 and 2 (each within the scatter of the next); then compound 4.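

In this assay, among these compounds, this position turns out to be less forgiving than the earlier compounds suggested: they could not be told apart, but benzylsulfanyl stands clearly apart from both cyclopentyloxy (a 2.7-fold higher number from compound 2 to compound 4 (0.43 log units; beyond the scatter)) and pyrrolidin-1-yl (a 3.3-fold higher number from compound 1 to compound 4 (0.52 log units; beyond the scatter)). The most telling comparison is with the other benzyl-type group (a 5.0-fold higher number from compound 3 to compound 4 (0.70 log units; beyond the scatter)), which shows that a benzyl-type group at this place does not by itself keep the number low, although this step both puts sulfur in place of oxygen and removes the ring fluorine. Nothing available here explains why compound 4 gives the highest number of the four.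

It remains open which of those two differences accounts for the step from compound 3, and a plain benzyloxy group or a (4-fluorobenzyl)sulfanyl group at this place would separate them. Going by these compounds, it is also open whether sulfur in place of oxygen matters without the benzyl group, which a cyclopentylsulfanyl group could be compared with compound 2 to show.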